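This account rests on a few compounds, and the source may have more. Where it says the series, first, only, none or still open, it means among the compounds named here.

In a physicochemical assay for solubility, read by spectrophotometry, in phosphate buffer, measured as kinetic solubility, with a stated time of 18 h, at pH 7.4 (a lower number here means a less soluble compound, a higher number a more soluble compound), compound 1 (`O=C(Nc1cccc(-c2ccccc2)c1)c1cc([N+](=O)[O-])ccc1Cl`) gives 410 nM and compound 2 (`O=C(Nc1cccc(-c2nc3ccccc3o2)c1)c1cc([N+](=O)[O-])ccc1Cl`) gives 470 nM so that neither stands apart from the other. Compound 3 (`O=C(Nc1cccc(-c2nc3ccccc3[nH]2)c1)c1cc([N+](=O)[O-])ccc1Cl`) has 1H-benzimidazol-2-yl in place of 1,3-benzoxazol-2-yl on an aromatic carbon. Among the compounds with values here, the one measured step that bears on this change (a 1.1-fold higher number from compound 1 to compound 2 (0.06 log units; within the scatter)) put 1,3-benzoxazol-2-yl in place of phenyl on an aromatic carbon. From that step no change beyond the scatter is expected in this assay in either direction. The estimated step (a 1.0-fold lower number from compound 2 to compound 3 (0.02 log units; within the scatter)) stays within the scatter. Compound 3 is estimated at 450 nM (expected range 180 nM to 1100 nM).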

Compound 3, solubility: 1400 nM
The estimate for compound 3 lay 3.1-fold (0.49 log units) below the measured number; measured number above the stated range.
By their numbers in this assay, from the lowest: compounds 1 and 2 (each within the scatter of the next); then compound 3.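

In this assay, this place on the ring proves sensitive to the group it carries: 1H-benzimidazol-2-yl in place of 1,3-benzoxazol-2-yl gives a 3.0-fold higher number from compound 2 to compound 3 (0.47 log units; beyond the scatter), and the same group in place of phenyl gives a 3.4-fold higher number from compound 1 to compound 3 (0.53 log units; beyond the scatter). Both steps lie beyond the scatter, and the ring sizes stay the same in the first, where the entering group carries a hydrogen-bond donor that the leaving group lacks. Nothing available here accounts for the higher number. Going by these compounds, whether the hydrogen on the ring nitrogen matters stays open, and how a 1-methyl-1H-benzimidazol-2-yl group or a simple amine at this place would compare also remains unknown.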